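The source may hold more compounds than are shown below. What is called first, only, known or untested is meant among the compounds shown, and "the series" means these compounds.

Of the compounds shown here, two with a shared core have been tested in a functional assay on K562 cells (Homo sapiens) for cytotoxicity, read by MTT assay, with a stated time of 72 h; a lower number here means a stronger inhibitor, a higher number a weaker inhibitor. Compound 1 `O=C(CN1C(=O)/C(=C/c2ccc(-c3ccc(Cl)cc3)o2)SC1=S)NCc1ccc(C(F)(F)F)cc1` carries a trifluoromethyl group and in this assay compound 1 gives 155000 nM. Compound 2 `COc1ccc(CNC(=O)CN2C(=O)/C(=C/c3ccc(-c4ccc(Cl)cc4)o3)SC2=S)cc1` carries a methoxy group in its place, and in this assay compound 2 gives 40000 nM. For the measured compounds named here, the single measured step, a 3.9-fold lower number from compound 1 to compound 2 (0.59 log units; beyond the scatter), is the only comparison available, and it leaves compound 2 with the lowest of the two numbers, the nearest being compound 1.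

Compound 3 `O=C(CN1C(=O)/C(=C/c2ccc(-c3ccc(Cl)cc3)o2)SC1=S)NCc1ccc(Br)cc1` differs from compound 2 in one place: bromo in place of methoxy on an aromatic carbon. Going by the values given here, no measured step involves a bromo group, so the step from compound 1 to compound 2 bears on this change only in showing that swapping the group at this position can move the number by a modest amount. With nothing that points to a direction, the step of a 1.5-fold higher number from compound 2 to compound 3 (0.18 log units; within the scatter) is expected to stay close to the scatter, with a slight lean back toward the number of compound 1. The estimate for compound 3 in this assay is therefore 60000 nM, with a range from 20000 nM to 200000 nM.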

Compound 3, half-maximal inhibitory concentration: 68000 nM
For compound 3 the middle estimate is 1.1-fold (0.05 log units) below the measured one; the measured number falls inside the stated range.
By their numbers in this assay, from the lowest: compounds 2 and 3 (each within the scatter of the next); then compound 1.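

In this assay, swapping methoxy for bromo on this aromatic carbon gives a 1.7-fold higher number from compound 2 to compound 3 (0.23 log units; within the scatter), so these two groups cannot be told apart here, even though one carries a hydrogen-bond acceptor and the other does not. The other new comparison, a 2.3-fold lower number from compound 1 to compound 3 (0.36 log units; beyond the scatter), shows that the gap from the trifluoromethyl compound is not unique to methoxy, since bromo also stands clear of trifluoromethyl by more than the scatter, and among these three compounds, trifluoromethyl is therefore the one that stands apart. Nothing available explains why trifluoromethyl gives the highest number of the three.

For the compounds shown here, with only three groups at this one place on the ring, it remains open whether the number can be pushed well below those of compound 2 and compound 3 , or whether they mark a floor for this series. An amine, a carboxylic acid, a plain hydrogen or a longer chain at the same place would test this, and would show whether methoxy and bromo matching here is a general feature of the position or a coincidence of these two groups.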